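The source may hold more compounds than are shown below. What is called first, only, known or untested is meant among the compounds shown, and "the series" means these compounds.

Working notes on the series. Compound 1 `COC(=O)/C=C/c1cccc(N(Cc2ccc(/C=C/c3c(Cl)cccc3Cl)cc2)C(=O)C(C)C)c1` carries the 2,6-dichlorophenyl on the ethenyl chain and gives 195 nM in an assay on isolated protein with Bile acid receptor (Homo sapiens) as the target; on this read-out higher numbers stand for an effect only at larger amounts of compound and lower numbers for an effect already at smaller amounts. Compound 2 `COC(=O)/C=C/c1cccc(N(Cc2ccc(/C=C/c3ccc(F)cc3)cc2)C(=O)C(C)C)c1` gives 120 nM, and compound 3 `COC(=O)/C=C/c1cccc(N(Cc2ccc(/C=C/c3scnc3C)cc2)C(=O)C(C)C)c1` gives 228 nM. The steps of a 1.6-fold lower number from compound 1 to compound 2 (0.21 log units; within the scatter), a 1.2-fold higher number from compound 1 to compound 3 (0.07 log units; within the scatter) and a 1.9-fold higher number from compound 2 to compound 3 (0.28 log units; within the scatter) all stay within the scatter, so compound 3 sits among the other two without any separation that can be read. Compound 4 `COC(=O)/C=C/c1cccc(N(Cc2ccc(-c3ccc(SC)cc3)cc2)C(=O)C(C)C)c1` brings (4-(methylsulfanyl)phenyl in place of 2-(4-methyl-1,3-thiazol-5-yl)ethenyl on an aromatic carbon). Among the compounds with values here, no measured step removes the double bond or replaces the whole chain, so none bears on this change directly; the three exchanges of the aryl group on the ethenyl chain only show that such exchanges moved nothing beyond the scatter. The step of a 1.1-fold lower number from compound 3 to compound 4 (0.06 log units; within the scatter) is therefore expected to remain within the scatter. Compound 4 is estimated at 200 nM in this assay, with a range from 70 nM to 600 nM.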

Compound 4, half-maximal effective concentration: 51 nM
For compound 4 the middle estimate is 3.9-fold (0.59 log units) above the measured one; the measured number lies below the stated range.
By their numbers in this assay, from the lowest: compound 4; then compounds 2, 1 and 3 (each within the scatter of the next).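

Within the data shown here, exchanging the whole aryl-ethenyl chain for 4-(methylsulfanyl)phenyl on this aromatic carbon is the first change to move the number in this assay beyond the scatter (a 4.5-fold lower number from compound 3 to compound 4 (0.65 log units; beyond the scatter); a 3.8-fold lower number from compound 1 to compound 4 (0.58 log units; beyond the scatter); a 2.4-fold lower number from compound 2 to compound 4 (0.37 log units; beyond the scatter)). All three steps run the same way, whichever aryl group the ethenyl chain carried, so this position responds to replacing the chain where exchanges of the aryl group alone moved nothing readable. Nothing at hand explains the lower number.

Compound 4 loses the double bond and changes the aryl group at once, leaving their separate contributions open. Also open, going by these compounds, is whether a methoxy group or a carboxylic acid in place of the methylsulfanyl would keep the number this low.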